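Moving a methyl on the dimethylphenyl group

The source may hold more compounds than are shown below. What is called first, only, known or untested is meant among the compounds shown, and "the series" means these compounds.

Compound 1 `Cc1cc(-c2ccc(F)cc2)c(/C=C/[C@@H]2C[C@@H](O)CC(=O)O2)c(C(C)C)n1` gives 9 nM in an assay for inhibition of 3-hydroxy-3-methylglutaryl-coenzyme A reductase (Rattus norvegicus); on this read-out higher numbers stand for weaker inhibition and lower numbers for stronger inhibition. Compound 2 `CC(C)c1nc(-c2ccc(F)cc2)cc(-c2ccc(F)cc2)c1/C=C/[C@@H]1C[C@@H](O)CC(=O)O1` gives 2 nM in this assay, and compound 3 `Cc1ccc(C)c(-c2cc(-c3ccc(F)cc3)c(/C=C/[C@@H]3C[C@@H](O)CC(=O)O3)c(C(C)C)n2)c1` gives 5 nM in this assay. Among these three numbers compound 3 stands second highest: its nearest neighbour is compound 1, and the step of a 1.8-fold lower number from compound 1 to compound 3 (0.26 log units; within the scatter) lies within the scatter, whereas the step of a 2.5-fold higher number from compound 2 to compound 3 (0.40 log units; beyond the scatter) lies beyond it. The remaining step, a 4.5-fold lower number from compound 1 to compound 2 (0.65 log units; beyond the scatter), is modest as well.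

Compound 4 `Cc1cc(C)cc(-c2cc(-c3ccc(F)cc3)c(/C=C/[C@@H]3C[C@@H](O)CC(=O)O3)c(C(C)C)n2)c1` differs from compound 3 by 3,5-dimethylphenyl in place of 2,5-dimethylphenyl on an aromatic carbon. Going by the values given here, no measured step exchanges one dimethylphenyl isomer for another at this place. Among the compounds with values here, the steps that bear on the position are the replacements of methyl, a 4.5-fold lower number from compound 1 to compound 2 (0.65 log units; beyond the scatter) and a 1.8-fold lower number from compound 1 to compound 3 (0.26 log units; within the scatter), and the exchange a 2.5-fold higher number from compound 2 to compound 3 (0.40 log units; beyond the scatter); all three are modest or within the scatter, so the position appears to accept several groups without large shifts. For a swap between two dimethylphenyl isomers no step beyond the scatter is therefore expected in this assay, and the expected step is no change at the digits printed from compound 3 to compound 4 (within the scatter). Compound 4 is accordingly estimated at 5 nM, with a range from 2 nM to 12 nM.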

Compound 4, half-maximal inhibitory concentration: 8 nM
The estimate for compound 4 lay 1.6-fold (0.20 log units) below the measured number, and the stated range covers the measured number.
By their numbers in this assay, from the lowest: compound 2; then compounds 3, 4 and 1 (each within the scatter of the next).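

In this assay, going by these compounds alone, the first direct exchange of one dimethylphenyl isomer for another, on the aromatic carbon next to the ring nitrogen, is a 1.6-fold higher number from compound 3 to compound 4 (0.20 log units; within the scatter) and leaves the two isomers indistinguishable, so relocating one methyl on this ring has no resolvable effect here. The 3,5-dimethylphenyl group also cannot be told apart from the much smaller methyl, with a 1.1-fold lower number from compound 1 to compound 4 (0.05 log units; within the scatter) as the step, while a 4.0-fold higher number from compound 2 to compound 4 (0.60 log units; beyond the scatter) is a modest step beyond the scatter and places compound 2, with its 4-fluorophenyl group, apart from all three other compounds. The data at hand offer no explanation for why 4-fluorophenyl stands apart from both dimethylphenyl isomers and methyl at this place.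

Two dimethylphenyl isomers cannot show whether other arrangements, such as 2,6-dimethylphenyl, would remain equally close to these values. As far as these compounds go, it also remains open whether a phenyl ring carrying an amine or a carboxylic acid, or a longer alkyl chain in place of the ring, would be accepted at this position as readily as the groups compared here.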